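This account rests on a few compounds, and the source may have more. Where it says the series, first, only, none or still open, it means among the compounds named here.

Measured in an assay on CHO cells for antagonist activity at transient receptor potential cation channel subfamily V member 1 (Homo sapiens), read by FLIPR; a higher number here means a weaker inhibitor, a lower number a stronger inhibitor:

Compound 1 `CC(C(=O)NCc1ccc(C(F)(F)F)cc1OC1CCCCC1)c1ccc(NS(C)(=O)=O)c(F)c1`: 0.7 nM
Compound 2 `CC(C)CCSc1cc(C(F)(F)F)ccc1CNC(=O)C(C)c1ccc(NS(C)(=O)=O)c(F)c1`: 1.4 nM
Compound 3 `CC(C(=O)NCc1ccc(C(F)(F)F)cc1SCc1ccccc1)c1ccc(NS(C)(=O)=O)c(F)c1`: 0.5 nM

Compound 3 gives the lowest of the three numbers, but the gap to compound 1 is within the scatter a 1.4-fold lower number from compound 1 to compound 3 (0.15 log units; within the scatter), while the gap to compound 2 is beyond it a 2.8-fold lower number from compound 2 to compound 3 (0.45 log units; beyond the scatter). Compound 4 `COc1ccc(-c2cc(C(F)(F)F)ccc2CNC(=O)C(C)c2ccc(NS(C)(=O)=O)c(F)c2)cc1OC` differs from compound 3 in one place: 3,4-dimethoxyphenyl in place of benzylsulfanyl on an aromatic carbon. Every measured step changes this same aromatic carbon, and all are small: a 2.0-fold higher number from compound 1 to compound 2 (0.30 log units; within the scatter) and the two steps just given. None of them involves 3,4-dimethoxyphenyl, so no direction can be read from them; a step of modest size at most is expected. For compound 4 the estimate in this assay is 1 nM, within 0.3 nM to 4 nM, which is expected to mean a 2.0-fold higher number from compound 3 to compound 4 (0.30 log units; within the scatter).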

Compound 4, inhibition constant: 8.6 nM
Compound 4: the middle estimate sits 8.6-fold (0.93 log units) below what was measured; the whole stated range lies below it.
By their numbers in this assay, from the lowest: compounds 3, 1 and 2 (each within the scatter of the next, the first and the last beyond it); then compound 4.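

At this aromatic carbon, cyclohexyloxy, isopentylsulfanyl and benzylsulfanyl differ by modest steps at most in this assay, but 3,4-dimethoxyphenyl brings the first clear weakening: a 17-fold higher number from compound 3 to compound 4 (1.24 log units; beyond the scatter), a 12-fold higher number from compound 1 to compound 4 (1.09 log units; beyond the scatter) and a 6.1-fold higher number from compound 2 to compound 4 (0.79 log units; beyond the scatter). Within the data shown here, the position is therefore not indifferent to its substituent, and compound 4 is the only one here whose group joins this carbon through a ring carbon rather than through oxygen or sulfur. Nothing measured here explains the weakening.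

On these data alone, it remains open whether the aromatic ring bound straight to this carbon or its two methoxy groups matter more; a plain phenyl or a 4-methoxyphenyl group here would help separate the two.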